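The source may report more compounds than this note shows. Statements on the series, on what has been measured and on what is new or still open speak of the compounds shown alone.

Measured compounds:
compound 1 `Cc1cc(-c2nc3sc(C)cn3c2/C=N/NC(=N)N)c(C)s1` gives 13500 nM
compound 2 `Cc1cn2c(/C=N/Nc3ccccn3)c(-c3ccc(Cl)c([N+](=O)[O-])c3)nc2s1` gives 38900 nM

In a functional assay on cells (Cancer cell lines, Homo sapiens) for inhibition (a higher number here means a weaker inhibitor of growth, a lower number a stronger inhibitor of growth), compound 1 stands at the lower of the two numbers, and compound 2 sits higher, a gap that lies beyond the usual scatter of the measurement. Compound 3 `Cc1cn2c(/C=N/NC(=N)N)c(-c3ccsc3)nc2s1` has not been measured yet. It differs from compound 1 in one place: thiophen-3-yl in place of 2,5-dimethylthiophen-3-yl on an aromatic carbon. The group that enters is the same five-membered ring without the two methyl substituents of the group that leaves; nothing else in the molecule changes. Among the compounds with values here, no measured pair shows what this exact change does, so the expectation rests only on its small size: a modest shift is expected, most likely toward a somewhat higher number, though one that may stay within the scatter. Compound 3 is therefore expected to give 20000 nM, with a range from 7000 nM to 60000 nM. The expected step is a 1.5-fold higher number from compound 1 to compound 3 (0.17 log units; within the scatter).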

Compound 3, concentration for total growth inhibition: 22400 nM
Compound 3: the middle estimate sits 1.1-fold (0.05 log units) below what was measured, and the stated range covers the measured number.
By their numbers in this assay, from the lowest: compounds 1, 3 and 2 (each within the scatter of the next, the first and the last beyond it).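

In this assay, putting thiophen-3-yl in place of 2,5-dimethylthiophen-3-yl gives a 1.7-fold higher number from compound 1 to compound 3 (0.22 log units; within the scatter), so the two methyl groups can go without a change that stands out from the scatter. Within the data shown here, this is the first pair here that differs in one place, and it offers the first direct reading of a change on this aromatic carbon of the five-membered ring with 2 nitrogen. No measurement at hand offers an explanation for this step.

Still open, from the compounds shown here alone, is whether a single methyl group on the thiophene would behave like none or like two. Going by these compounds, it is also open whether this place accepts a quite different group, such as a phenyl ring, an amine or a longer chain such as hexyl, and whether such a group would move the number beyond the scatter.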